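This account rests on a few compounds, and the source may have more. Where it says the series, first, only, none or still open, it means among the compounds named here.

In a functional assay on A549 cells (Homo sapiens) for inhibition, read by CCK-8 assay, with a stated time of 72 h, tested at 8 uM (a higher number here means more inhibition of growth at the concentration tested, a lower number less inhibition of growth), compound 1 (`COc1ccc(SCc2ccc(C(=O)Nc3ccccc3N)cc2)cc1`) gives 70.7%, compound 2 (`Cc1ccc(SCc2ccc(C(=O)Nc3ccccc3N)cc2)cc1`) gives 78.3% and compound 3 (`Nc1ccccc1NC(=O)c1ccc(CSc2ccc(Br)cc2)cc1`) gives 45.7%. Compound 3 stands lowest of the three, with a number 25 percentage points lower from compound 1 to compound 3 (beyond the scatter) and a number 32.6 percentage points lower from compound 2 to compound 3 (beyond the scatter). The remaining pair shows a number 7.6 percentage points higher from compound 1 to compound 2 (within the scatter).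

Compound 4 (`Nc1ccccc1NC(=O)c1ccc(CSCCc2ccccc2)cc1`) carries phenethyl in place of 4-bromophenyl on a sulfur. Going by the values given here, no measured step tests this kind of change, so the two bromo steps are the only guide, and the bromine leaves here. A rise short of full recovery is expected, with compound 1 at 70.7% as the nearest reference. The expected size is a number 14.3 percentage points higher from compound 3 to compound 4 (beyond the scatter). The estimate for compound 4 is 60%, within an expected range of 40% to 80%.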

Compound 4, percent growth inhibition at one concentration: 84.1%
Beside the measured number, compound 4's estimate is 24.1 percentage points below it; the whole stated range lies below it.
By their numbers in this assay, from the lowest: compound 3; then compounds 1, 2 and 4 (each within the scatter of the next, the first and the last beyond it).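

In this assay phenethyl on the sulfur lifts growth inhibition well above the 4-bromophenyl level, with a number 38.4 percentage points higher from compound 3 to compound 4 (beyond the scatter) and so the sulfur need not carry an aromatic ring itself. The same change gives a number 13.4 percentage points higher from compound 1 to compound 4 (beyond the scatter) against 4-methoxyphenyl and a number 5.8 percentage points higher from compound 2 to compound 4 (within the scatter) against 4-methylphenyl, so phenethyl gives up nothing to either group. No measurement at hand explains these steps.

As far as these compounds go, whether the chain or the loss of bromine carries the rise stays open. Unsubstituted phenyl, benzyl or a longer chain such as phenylpropyl on the sulfur would separate the two.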